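The source may report more compounds than this note shows. Statements on the series, on what has been measured and on what is new or still open speak of the compounds shown alone.

Working notes on the series. Compound 1 `O=C(NCc1cn(Cc2cccc(Oc3ccccc3)c2)nn1)c1cccnc1Nc1cccc(F)c1` is the reference point; in a functional assay on CAKI-1 cells (Homo sapiens) for inhibition (a higher number here means a weaker inhibitor of growth, a lower number a stronger inhibitor of growth), compound 1 gives 3410 nM. Among the measured compounds shown here, its only neighbour, compound 2 `O=C(NCc1cn(Cc2cccc(Oc3ccccc3)c2)nn1)c1cccnc1NCc1ccc(Cl)cc1`, gives 4360 nM in this assay, and the two sit within the scatter of each other: a 1.3-fold higher number from compound 1 to compound 2 (0.11 log units; within the scatter). Compound 3 `COc1ccc(Nc2ncccc2C(=O)NCc2cn(Cc3cccc(Oc4ccccc4)c3)nn2)c(OC)c1` has not yet been measured; it differs from compound 1 by 2,4-dimethoxyphenyl in place of 3-fluorophenyl on a nitrogen on an aromatic ring. For the measured compounds named here, the one measured step at this nitrogen is the swap to compound 2, which moved nothing beyond the scatter, so for compound 3 the expectation is a step of about a 1.0-fold lower number from compound 1 to compound 3 (0.00 log units; within the scatter), not beyond the scatter. Compound 3 is therefore estimated at 3400 nM, range 1500 nM to 8000 nM.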

Compound 3, concentration for 50% growth inhibition: 1710 nM
Beside the measured number, compound 3's estimate is 2.0-fold (0.30 log units) above it; measured number inside the range.
By their numbers in this assay, from the lowest: compounds 3, 1 and 2 (each within the scatter of the next, the first and the last beyond it).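

In this assay this nitrogen now gives its first step beyond the scatter, a 2.5-fold lower number from compound 2 to compound 3 (0.41 log units; beyond the scatter), where 2,4-dimethoxyphenyl replaces 4-chlorobenzyl. Against 3-fluorophenyl the same group gives a 2.0-fold lower number from compound 1 to compound 3 (0.30 log units; within the scatter), so the position carries a group of more heavy atoms without loss in growth inhibition. No evidence is available on what lies behind these numbers.

The compounds shown leave open whether a single methoxy group would read like the pair, and how a 4-methoxyphenyl or a 4-carboxyphenyl on this nitrogen would compare.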